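Removing the Benzoyl Group: Expecting Compound 4 in This Assay

A few compounds are considered here, and "the series" means these few. Any claim that something is new, unique, unknown or untested is made for them only; others in the source may bear on it.

Measured compounds:
compound 1 `CC(=O)Oc1ccccc1-c1cc2ccccc2[nH]1` — 31000 nM
compound 2 `O=C(Oc1ccccc1-c1cc2ccccc2[nH]1)c1ccccc1` — 39000 nM
compound 3 `Oc1ccccc1-c1ccc2ccccc2c1` — 92000 nM

Of the compounds shown here, three have been measured in a functional assay on U-251 cells (Homo sapiens) for antiproliferative activity, read by sulforhodamine B assay, with a stated time of 72 h; a lower number here means that less compound is needed, a higher number that more compound is needed for the effect. Compound 2 stands second highest of the three; its nearest neighbour is compound 1, whose number lies close enough to be within the scatter, while compound 3 gives the furthest number, beyond the scatter. Compound 4 `Oc1ccccc1-c1cc2ccccc2[nH]1` is not yet measured. It differs from compound 2 by hydrogen in place of benzoyl on an oxygen on an aromatic ring.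

Among the compounds with values here, only one measured step bears on this change. The step of a 1.3-fold higher number from compound 1 to compound 2 (0.10 log units; within the scatter) shows that exchanging the group on the same oxygen between two acyl variants makes no difference beyond the scatter. Within the data shown here, no measured step removes the group on the oxygen entirely, so the value of compound 4 in this assay can only be inferred loosely. Among the measured compounds shown here, compound 3, which carries a free hydroxyl on a different core, gives 92000 nM, but no step connects it to compound 2.

For compound 4 the expected step is therefore a 1.1-fold lower number from compound 2 to compound 4 (0.05 log units; within the scatter), none beyond the scatter. Compound 4 is estimated at 35000 nM, with a range from 12000 nM to 100000 nM.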

Compound 4, half-maximal effective concentration: 130000 nM
The estimate for compound 4 lay 3.7-fold (0.57 log units) below the measured number; measured number above the stated range.
By their numbers in this assay, from the lowest: compounds 1 and 2 (each within the scatter of the next); then compounds 3 and 4 (each within the scatter of the next).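

In this assay, within the data shown here, the free hydroxyl is the first change at this oxygen on the aromatic ring to move the number beyond the scatter: hydrogen in place of benzoyl gives a 3.3-fold higher number from compound 2 to compound 4 (0.52 log units; beyond the scatter) and hydrogen in place of acetyl gives a 4.2-fold higher number from compound 1 to compound 4 (0.62 log units; beyond the scatter). Exchanging one acyl group for the other gave only a 1.3-fold higher number from compound 1 to compound 2 (0.10 log units; within the scatter), so among these three compounds, having an acyl group on this oxygen counts for more than which of the two it is. Nothing shown here gives a measured reason for the rise on removing either group.

The compounds shown leave open whether other groups on this oxygen, such as a methyl ether or a carbamate, would give numbers like those of the two acyl compounds or like that of the free hydroxyl. They also leave open whether removing an acyl group has a similar effect on another core, for compound 3 has its free hydroxyl on a different core and no acyl partner among them.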